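Removing the Methylene Link from a Tetrazole Hydroxamate

The source may report more compounds than this note shows. Statements on the series, on what has been measured and on what is new or still open speak of the compounds shown alone.

In an assay on Sf9 cells for inhibition of protein deacetylase HDAC6 (Homo sapiens), read by fluorescence (on this read-out higher numbers stand for weaker inhibition and lower numbers for stronger inhibition), compound 1 `O=C(NO)c1ccc(Cn2nnc(Cc3ccccc3)n2)cc1` gives 52 nM, and compound 2 `O=C(NO)c1ccc(Cn2nnc(Cc3ccccn3)n2)cc1` gives 25 nM, the lower of the two numbers; the change between them is a 2.1-fold lower number from compound 1 to compound 2 (0.32 log units; beyond the scatter). Compound 3 `O=C(NO)c1ccc(Cn2nnc(-c3ccccn3)n2)cc1` differs from compound 2 by pyridin-2-yl in place of (pyridin-2-yl)methyl on an aromatic carbon. Within the data shown here, no measured step bears on this change: the only step, from compound 1 to compound 2, altered the ring itself and kept the saturated chain carbon. Lacking a guide, no step beyond the scatter is expected, a 1.2-fold higher number from compound 2 to compound 3 (0.08 log units; within the scatter). Compound 3 is therefore estimated at 30 nM, within 10 nM to 100 nM.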

Compound 3, half-maximal inhibitory concentration: 9 nM
The estimate for compound 3 lay 3.3-fold (0.52 log units) above the measured number, and the stated range ends above it.
By their numbers in this assay, from the lowest: compound 3; then compound 2; then compound 1.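

Taking out the saturated chain carbon, so that pyridin-2-yl sits directly on the aromatic carbon of the five-membered ring, gives a 2.8-fold lower number from compound 2 to compound 3 (0.44 log units; beyond the scatter) in this assay, which shows that the link is not needed for inhibition at this position. Replacing benzyl with pyridin-2-yl gives a 5.8-fold lower number from compound 1 to compound 3 (0.76 log units; beyond the scatter), the widest gap among these compounds. Nothing at hand accounts for this gain. On these data alone, whether phenyl set directly on the same carbon would match pyridin-2-yl stays open, as does the outcome of a longer chain or an amine at this position.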